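A few compounds are considered here, and "the series" means these few. Any claim that something is new, unique, unknown or untested is made for them only; others in the source may bear on it.

Compound 3 `Nc1cc(N)c2nc(-c3ccccc3)c(Sc3ccc(Cl)c(Cl)c3)nc2c1` carries a (3,4-dichlorophenyl)sulfanyl group on the shared core. In a functional assay on M14 cells (Homo sapiens) for inhibition, read by sulforhodamine B assay, with a stated time of 48 h (on this read-out lower numbers stand for stronger inhibition of growth and higher numbers for weaker inhibition of growth), compound 3 gives < 100000 nM, which is a limit of the assay and not a number. Compound 1 `Nc1cc(N)c2nc(-c3ccccc3)c(Oc3ccc(Cl)c(Cl)c3)nc2c1`, with a 3,4-dichlorophenoxy group in that place, gives 70800 nM in this assay. Compound 2 `CCOC(=O)[C@H](CCC(=O)O)NC(=O)c1ccc(Sc2nc3cc(N)cc(N)c3nc2-c2ccccc2)cc1` gives < 100000 nM in this assay, again a limit. The step that the limit leaves unreadable from compound 1 to compound 3 is thus unreadable in size. Compound 4 `Nc1cc(N)c2nc(-c3ccccc3)c(Sc3ccc(F)cc3)nc2c1` differs from compound 3 by 4-fluorophenyl in place of 3,4-dichlorophenyl on a sulfur. No measured step covers this change, and the limit of < 100000 nM in this assay, at which 2 of the 3 values shown sit, leaves the shown values without a clear anchor. Compound 4 is therefore expected to stay in a similar range, with a step that the limit leaves unreadable from compound 3 to compound 4 of uncertain direction. Compound 4 is estimated at 60000 nM, between 15000 nM and 100000 nM.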

Compound 4, concentration for total growth inhibition: 30900 nM
The estimate for compound 4 lay 1.9-fold (0.29 log units) above the measured number; low and high end bracket the measured number.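

With a readable value at this position, the sulfur-linked series now has a real number, and a 2.3-fold lower number from compound 1 to compound 4 (0.36 log units; beyond the scatter) marks a lower number and so stronger growth inhibition in this assay. That step changes both the linking atom and the ring's halogens at once, so it belongs to the whole swap of 3,4-dichlorophenoxy for (4-fluorophenyl)sulfanyl. Compound 3 gives < 100000 nM, a limit of the assay and not a number, so its step to compound 4 cannot be read.

Which part of the swap, the sulfur or the 4-fluorophenyl ring, accounts for the step stays open. So does the effect of a nitrile or a methoxy group in place of the fluorine on that ring.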